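Replacing an ethyl ester with a sulfamoyl group on a phenyl urea

The compounds below may be only part of what the source reports. "The series", "measured", "known", "first", "only" and "open" are said of these compounds alone.

The measured compounds:
Compound 1, `CCOC(=O)CNC(=O)N1CC1C#N`, gives 51000 nM in a functional assay on A-375 cells (Homo sapiens) for inhibition; on this read-out lower numbers stand for stronger inhibition and higher numbers for weaker inhibition.
Compound 2, `CCOC(=O)c1ccc(NC(=O)N2CC2C#N)cc1`, gives 5800 nM in this assay.
Compound 3, `N#CC1CN1C(=O)Nc1ccc(Cl)cc1Cl`, gives only a limit of the assay, > 39000 nM, in this assay.

Among the two actual numbers in this assay, compound 2 holds the lower one, and the gap to compound 1 lies beyond the usual scatter. Compound 3 sits at the limit of > 39000 nM in this assay, at which 1 of the 3 values shown sits, so for it no number is known.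

Compound 4, `N#CC1CN1C(=O)Nc1ccc(S(N)(=O)=O)cc1`, has not yet been measured in this assay. It differs from compound 2 in one place: sulfamoyl in place of ethoxycarbonyl on an aromatic carbon. Among the compounds with values here, none of the measured compounds shows a comparable change, so there is no measured step to lean on. The expected step from compound 2 to compound 4 in this assay is a 2.1-fold higher number from compound 2 to compound 4 (0.32 log units; beyond the scatter), most likely a small shift toward weaker inhibition, though a result within the scatter would not surprise. Compound 4 is therefore estimated at 12000 nM, with a range from 2500 nM to 60000 nM.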

Compound 4, half-maximal inhibitory concentration: 188000 nM
The estimate for compound 4 lay 16-fold (1.19 log units) below the measured number; the measured number lies above the stated range.
By their numbers in this assay, from the lowest: compound 2; then compound 1; then compound 4.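

In this assay, within the data shown here, the group on this aromatic carbon turns out to matter far more than the earlier compounds could show: sulfamoyl in place of ethoxycarbonyl gives a 32-fold higher number from compound 2 to compound 4 (1.51 log units; beyond the scatter), a large step toward weaker inhibition. Among these compounds, this is the first measured change at this place, so inhibition here clearly depends on which group is present, and the two groups are not interchangeable. Sulfamoyl carries 1 hydrogen-bond donor and ethoxycarbonyl 0, but nothing measured here explains why the step is so large.

A single step cannot tell which feature of either group is responsible. A carboxylic acid, an acetyl group or a methyl sulfonyl group on the same carbon could show whether ethoxycarbonyl is unusually favourable or sulfamoyl unusually poor.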